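The source may hold more compounds than are shown below. What is called first, only, known or untested is meant among the compounds shown, and "the series" means these compounds.

Compound 3, `COc1ccc(Nc2nc(Oc3cccc(NC(=O)C=C(C)C)c3)c3sccc3n2)cn1`, is known in a functional assay on HeLa cells (Homo sapiens) for inhibition, read by MTT assay, with a stated time of 72 h (on this read-out higher numbers stand for weaker inhibition and lower numbers for stronger inhibition), only as a limit: in this assay compound 3 gives > 100000 nM, which is the limit of the assay and not a number, as noted in the limit of > 100000 nM in this assay, at which 1 of the 3 values shown sits. The two compounds with numbers share its core but carry methoxyphenyl groups in place of its pyridyl ring and the longer acyl chain. Compound 1, `COc1ccc(Nc2nc(Oc3cccc(NC(=O)/C=C/C(C)C)c3)c3sccc3n2)cc1`, gives 45100 nM in this assay. Compound 2, `COc1cccc(Nc2nc(Oc3cccc(NC(=O)/C=C/C(C)C)c3)c3sccc3n2)c1`, gives 27000 nM in this assay. Going by the values given here, the one single-point step among them, a 1.7-fold lower number from compound 1 to compound 2 (0.22 log units; within the scatter), moves a group on the aromatic nitrogen and lies within the scatter.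

Compound 4, `COc1ccc(Nc2nc(Oc3cccc(NC(=O)/C=C/C(C)C)c3)c3sccc3n2)cn1`, differs from compound 3 by 3-methylbut-1-en-1-yl in place of 2-methylprop-1-en-1-yl on a carbonyl carbon, that is, a 3-methylbut-1-en-1-yl in place of 2-methylprop-1-en-1-yl on a carbonyl carbon. Among the compounds with values here, no measured step changes this acyl group alone; the step from compound 1 to compound 2 concerns another place, and compound 3 offers only a limit. Compound 4 carries the same acyl chain as compounds 1 and 2, whose values sit near the top of the measured range, so compound 4 is expected to give an inhibitory concentration near the limit, with the step of an at least 1.2-fold lower number from compound 3 to compound 4 (0.09 log units; that floor lies within the scatter) uncertain in direction. The estimate for compound 4 in this assay is 80000 nM, with a range from 30000 nM to 200000 nM.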

Compound 4, half-maximal inhibitory concentration: > 50000 nM
Compound 4 was reported as a limit (the forecaster's own chance of this, stated with the estimate: 40%); the middle value does not contradict the limit.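

In this assay, compound 4 is reported only as a limit: the limit of > 50000 nM in this assay, at which 1 of the 4 values shown sits.

With the 3-methylbut-1-en-1-yl chain held constant, 6-methoxypyridin-3-yl in place of 3-methoxyphenyl on the nitrogen gives an at least 1.8-fold higher number from compound 2 to compound 4 (0.26 log units; that floor lies within the scatter), and the same group in place of 4-methoxyphenyl gives an at least 1.1-fold higher number from compound 1 to compound 4 (0.04 log units; that floor lies within the scatter). These are the first steps shown at this position that exchange the methoxyphenyl group for a 6-methoxypyridin-3-yl group, and neither gives a lower number, although both floors lie within the scatter, so a real rise in the number is not established.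

Compound 3 is also known only as a limit, so the step to compound 4 cannot be read, and the change from 2-methylprop-1-en-1-yl to 3-methylbut-1-en-1-yl on the carbonyl carbon remains without a size: the limit of > 100000 nM in this assay, at which 1 of the 4 values shown sits.

Also open is whether a morpholine or a dimethylamino group in place of the methoxy group, or a longer chain on the carbonyl carbon, would bring the number down to a measurable value well below those of the compounds shown.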